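Pyridin-2-yl for pyridin-3-yl: compound 3 to compound 4

A few compounds are considered here, and "the series" means these few. Any claim that something is new, unique, unknown or untested is made for them only; others in the source may bear on it.

For the measured compounds named here, in an assay on HEK293 cells for inhibition of Steryl-sulfatase (Homo sapiens), tested at 0.1 uM (on this read-out higher numbers stand for a stronger effect at the one concentration tested and lower numbers for a weaker effect), compound 3 `CCN(Cc1cccnc1)c1cccc(C(=O)N2CCc3ccc(OS(N)(=O)=O)cc3C2)c1` gives 14.3%, the lowest of the three numbers measured so far. Compound 1 `CN(CCCN1CCCCC1)c1cccc(C(=O)N2CCc3ccc(OS(N)(=O)=O)cc3C2)c1` gives 24.1% and compound 2 `CC(C)CCN(CCC(C)C)c1cccc(C(=O)N2CCc3ccc(OS(N)(=O)=O)cc3C2)c1` gives 32.3%. Both measured steps that reach compound 3, a number 9.8 percentage points lower from compound 1 to compound 3 (within the scatter) and a number 18 percentage points lower from compound 2 to compound 3 (beyond the scatter), exchanged the whole substituent on the aromatic carbon and still stayed small to modest. Compound 4 `CCN(Cc1ccccn1)c1cccc(C(=O)N2CCc3ccc(OS(N)(=O)=O)cc3C2)c1` keeps the same atoms: pyridin-2-yl in place of pyridin-3-yl on a saturated chain carbon bound to a nitrogen on an aromatic ring. Going by the values given here, no measured step moves only the position of the ring nitrogen, so there is no direct precedent; a change this confined is expected to do no more than the larger exchanges did. For compound 4 the expected step is a number 0.7 percentage points higher from compound 3 to compound 4 (within the scatter), no larger than the scatter, giving an estimate in this assay of 15%, between 3% and 30%.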

Compound 4, a percentage reported as inhibition, at one concentration (the size of the read-out at that concentration, not a potency): 6.5%
Compound 4: middle estimate off by 8.5 percentage points, on the high side; low and high end bracket the measured number.
By their numbers in this assay, from the lowest: compounds 4, 3, 1 and 2 (each within the scatter of the next, the first and the last beyond it).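

In this assay the move from pyridin-3-yl to pyridin-2-yl on the saturated chain carbon reads a number 7.8 percentage points lower from compound 3 to compound 4 (within the scatter) and does not separate the two groups. Against the larger substituents, a number 17.6 percentage points lower from compound 1 to compound 4 (beyond the scatter) and a number 25.8 percentage points lower from compound 2 to compound 4 (beyond the scatter) both clear the scatter, where the pyridin-3-yl group did so only against diisopentylamino. No evidence bears on these differences.

On these data alone, whether pyridin-4-yl or plain phenyl on that carbon would read alike stays open. So does the effect of a longer chain in place of the ethyl group.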